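Methoxy for nitro on the aryl ring of compound 3

A few compounds are considered here, and "the series" means these few. Any claim that something is new, unique, unknown or untested is made for them only; others in the source may bear on it.

In a functional assay on A549 cells (Homo sapiens) for cytotoxicity, read by sulforhodamine B assay, with a stated time of 2 days, tested at 100 uM (a higher number here means more inhibition at the concentration tested (going by the name of the read-out), a lower number less inhibition), three compounds have been measured. Compound 3 `O=C(Nn1c(-c2cccc([N+](=O)[O-])c2)nc2c(-c3ccc(Cl)cc3)n[nH]c2c1=O)c1ccccc1` gives 88.6%, the highest of the three. Compound 1 `COc1cccc(-c2nc3c(-c4ccc(Cl)cc4)n[nH]c3c(=O)n2NC(=O)c2ccncc2)c1` gives 46%, and compound 2 `CCCc1n[nH]c2c(=O)n(NC(=O)c3ccccc3)c(-c3cccc(OC)c3)nc12` gives 20.7%, both beyond the scatter below compound 3. Compound 4 `COc1cccc(-c2nc3c(-c4ccc(Cl)cc4)n[nH]c3c(=O)n2NC(=O)c2ccccc2)c1` has not yet been measured. It differs from compound 3 in one place: methoxy in place of nitro on an aromatic carbon. For the measured compounds named here, no measured pair shows this exact change, so the expected size of the step rests on the other compounds; compound 1, which carries the same methoxyphenyl group, gives a markedly lower number. Compound 4 is therefore expected to fall short of compound 3, by about a number 43.6 percentage points lower from compound 3 to compound 4 (beyond the scatter) in this assay. The estimate for compound 4 is 45%, within a range from 20% to 75%.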

Compound 4, a percentage reported as inhibition, at one concentration (the size of the read-out at that concentration, not a potency): 81.8%
Compound 4: the middle estimate sits 36.8 percentage points below what was measured, and the stated range ends below it.
By their numbers in this assay, from the lowest: compound 2; then compound 1; then compounds 4 and 3 (each within the scatter of the next).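

In this assay the swap of 3-nitrophenyl to 3-methoxyphenyl gives a number 6.8 percentage points lower from compound 3 to compound 4 (within the scatter) and so barely registers at this position, a step that stays within the scatter. The large steps lie in other places, with a number 35.8 percentage points higher from compound 1 to compound 4 (beyond the scatter) for phenyl in place of pyridin-4-yl on a carbonyl carbon and a number 61.1 percentage points higher from compound 2 to compound 4 (beyond the scatter) for 4-chlorophenyl in place of propyl on an aromatic carbon. Nothing at hand explains any of these steps. From the compounds shown here alone, whether an amine or a carboxylic acid on this aromatic carbon would give a similar number remains open. So does whether nitro and methoxy would also match with propyl or pyridin-4-yl elsewhere on the compound.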